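Ethoxycarbonyl to methoxycarbonyl: a small ester trim

A few compounds are considered here, and "the series" means these few. Any claim that something is new, unique, unknown or untested is made for them only; others in the source may bear on it.

In an ADME assay on a cell-free system (plasma, Homo sapiens) for metabolic stability, read by LC-MS (a higher number here means that the compound lasts longer, a lower number that the compound disappears faster), compound 3 (`CCOC(=O)c1cccc(-c2cc(C(=O)Nc3ccncc3)ccc2CN)c1`) stands at 0.683 h and so level, within the scatter, with compound 1 (`CCCCCCOC(=O)c1cccc(-c2cc(C(=O)Nc3ccncc3)ccc2CN)c1`) at 0.833 h. Compound 2 (`NCc1ccc(C(=O)Nc2ccncc2)cc1-c1cccc(C(=O)OCC2CCCCC2)c1`) stands at 1.65 h, a margin beyond the scatter from compound 3. Compound 4 (`COC(=O)c1cccc(-c2cc(C(=O)Nc3ccncc3)ccc2CN)c1`) differs from compound 3 thus: hydrogen in place of methyl on a saturated chain carbon bound to an oxygen next to a carbonyl group, ethoxycarbonyl becoming methoxycarbonyl. Within the data shown here, three measured steps bear on this. Cyclohexyl in place of pentyl gave a 2.0-fold higher number from compound 1 to compound 2 (0.30 log units; within the scatter), methyl in place of cyclohexyl gave a 2.4-fold lower number from compound 2 to compound 3 (0.38 log units; beyond the scatter), and hydrogen in place of butyl gave a 1.2-fold lower number from compound 1 to compound 3 (0.09 log units; within the scatter) as the result. Since only methyl leaves here, no step beyond the scatter is expected, and no firm direction. The step expected here is a 1.1-fold lower number from compound 3 to compound 4 (0.06 log units; within the scatter). In this assay compound 4 is estimated at 0.6 h, with 0.3 h to 1.2 h as the expected range.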

Compound 4, half-life: 1.52 h
The estimate for compound 4 lay 2.5-fold (0.40 log units) below the measured number, and the stated range ends below it.
By their numbers in this assay, from the lowest: compounds 3, 1, 4 and 2 (each within the scatter of the next, the first and the last beyond it).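

In this assay, the loss of a single methyl at this position is enough to give a 2.2-fold higher number from compound 3 to compound 4 (0.35 log units; beyond the scatter), so even the smallest trim of the ester registers here. The number does not follow the size of the group removed, since hydrogen in place of much larger groups gives only a 1.1-fold lower number from compound 2 to compound 4 (0.04 log units; within the scatter) and a 1.8-fold higher number from compound 1 to compound 4 (0.26 log units; within the scatter). Nothing available here accounts for this behaviour. Still open, from the compounds shown here alone, is whether the step from ethoxycarbonyl to methoxycarbonyl would recur in an isopropyl ester, or how an amide or a carboxylic acid in place of the ester would read.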